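Working notes: a series at its assay limit

The compounds below may be only part of what the source reports. "The series", "measured", "known", "first", "only" and "open" are said of these compounds alone.

Measured so far in a functional assay on MCF7 cells (Homo sapiens) for antiproliferative activity, read by MTT assay, with a stated time of 48 h (on this read-out higher numbers stand for weaker inhibition and lower numbers for stronger inhibition), with these results
- compound 1 `CN1CCN(CC(=O)Nc2ccc3ncnc(Nc4cccc(Cl)c4)c3c2)CC1` gives > 100000 nM as a limit
- compound 2 `CN1CCN(CC(=O)Nc2ccc3ncnc(Nc4ccc(Br)cc4)c3c2)CC1` gives > 100000 nM as a limit
- compound 3 `O=C(CN1CCCC1)Nc1ccc2ncnc(Nc3ccc(Cl)c(C(F)(F)F)c3)c2c1` gives > 100000 nM as a limit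

Compound 3 therefore stands at a limit and not at a number, and the series offers no other kind of reading, as the limit of > 100000 nM in this assay, at which 3 of the 3 values shown sit, makes plain here. Compound 4 `CN1CCN(CC(=O)Nc2ccc3ncnc(Nc4ccc(Cl)c(C(F)(F)F)c4)c3c2)CC1` has 4-methylpiperazin-1-yl in place of pyrrolidin-1-yl on a saturated chain carbon bound to a carbonyl carbon, counted as 4-methylpiperazin-1-yl in place of pyrrolidin-1-yl on a saturated chain carbon bound to a carbonyl carbon for this change. Within the data shown here, the one measured step, a step that the two limits leave unreadable from compound 1 to compound 2 in this series, has no readable size and concerns 4-bromophenyl in place of 3-chlorophenyl on a nitrogen on an aromatic ring, not this change. Compound 1 already carries 4-methylpiperazin-1-yl and gives > 100000 nM as a limit, so no readable gain in this assay is expected. The estimated change is a number no higher from compound 3 to compound 4 (the limit leaves the size open) and nothing beyond the scatter is expected. For compound 4 the expected value is 100000 nM within an estimated range of 30000 nM to 200000 nM and a report at the limit is the likeliest outcome.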

Compound 4, half-maximal inhibitory concentration: > 100000 nM
Compound 4 ended at the assay's limit; the forecaster's own chance of this, stated with the estimate: 75%; the middle value sits exactly at the limit.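

No step among compound 1, compound 2, compound 3 and compound 4 can be read, as each stands at a limit and not at a number: the limit of > 100000 nM in this assay, at which 4 of the 4 values shown sit.

The compounds shown leave open how far each lies past that limit, and whether 4-methylpiperazin-1-yl in place of pyrrolidin-1-yl, or one substituted phenyl for another, changes the read-out at all.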